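The source may report more compounds than this note shows. Statements on the series, on what has been measured and on what is new or still open speak of the compounds shown alone.

Measured so far:
- compound 1 `O=C(/C=C/c1ccc([N+](=O)[O-])cc1)c1ccc(O)c(O)c1`: in a functional assay on HT-29 cells (Homo sapiens) for cytotoxicity, read by resazurin assay, with a stated time of 48 h (a lower number here means that less compound is needed, a higher number that more compound is needed for the effect), compound 1 gives 8200 nM
- compound 2 `CC(=O)Nc1ccc(C(=O)/C=C/c2cccc([N+](=O)[O-])c2)cc1`: in this assay compound 2 gives 2000 nM

Compound 2 stands at the lowest of the two numbers. Compound 1 is the nearest, and its number is higher by a gap beyond the usual scatter of repeated measurements. Compound 1 and compound 2 differ in more than one place, so no step between measured compounds isolates any single change, and nothing shown here tells how much of that gap belongs to either difference.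

Compound 3 `O=C(/C=C/c1cccc([N+](=O)[O-])c1)c1ccc(NC(=O)c2ccccc2)cc1` keeps the core of compound 2 and differs from it in one place: phenyl in place of methyl on a carbonyl carbon. For the measured compounds named here, no measured pair shows what such an exchange does in this assay, so the expectation rests on compound 2 alone. With nothing to argue for a shift either way, the step is expected to be small, a 1.3-fold lower number from compound 2 to compound 3 (0.10 log units; within the scatter), and may well lie within the scatter. Compound 3 is therefore estimated at 1600 nM in this assay, with a range from 500 nM to 5000 nM.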

Compound 3, half-maximal effective concentration: 3900 nM
Compound 3: the middle estimate sits 2.4-fold (0.39 log units) below what was measured; the range from low to high includes it.
By their numbers in this assay, from the lowest: compounds 2 and 3 (each within the scatter of the next); then compound 1.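

For the compounds shown here, this is the first step that isolates a single change. In this assay, phenyl in place of methyl on the carbonyl carbon, read one bond further out as acetamido to benzamido, gives a 2.0-fold higher number from compound 2 to compound 3 (0.29 log units; within the scatter), so compound 2 and compound 3 cannot be told apart here, and this one position carries either a methyl or a six-membered aromatic ring of carbon only with no step beyond the scatter. Nothing measured alongside these compounds speaks to the reason for this result.

As far as these compounds go, what a longer alkyl chain, a carboxylic acid or a basic amine on this carbonyl carbon would give in this assay remains open, since two groups at one position define no trend, and a free amine in place of the whole acetamido group is equally open. From the compounds shown here alone, the steps from compound 1 to the other two compounds cannot be read, as it differs from each in more than one place, so whether the benzamido result carries over to another substitution on the shared core also stays open.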